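The source may report more compounds than this note shows. Statements on the series, on what has been measured and on what is new or still open speak of the compounds shown alone.

Working notes on the series. Of the compounds shown here, three have been measured so far: compound 1 `N=C(N)NCCC[C@H](NC(=O)CN(c1ncnc2c1ncn2C1CCCCO1)C1CC1)C(=O)OCc1ccccc1`, compound 2 `CC[C@H](C)[C@H](NC(=O)CN(c1ncnc2c1ncn2C1CCCCO1)C1CC1)C(=O)OCc1ccccc1` and compound 3 `O=C(O)C[C@H](NC(=O)CN(c1nc(Cl)nc2[nH]cnc12)C1CC1)C(=O)O`. In a functional assay on the whole organism (Tail, strain ICR) with Mus musculus as the target, in the tail flick test, with a stated time of 150 min, at a dose of 25 umol/kg by the oral route (a higher number here means a stronger effect of the compound at the dose given, a lower number a weaker effect), compound 1 gives 19.6%, compound 2 gives 16.4% and compound 3 gives 11.6%. The number for compound 2 sits between those of compound 1 and compound 3, and both gaps lie within the scatter, so no distinction among the three is supported. Among the measured compounds shown here, the only single-place step between measured compounds, a number 3.2 percentage points lower from compound 1 to compound 2 (within the scatter), exchanged a side group at the same position and stayed within the scatter.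

Compound 4 `O=C(CN(c1ncnc2c1ncn2C1CCCCO1)C1CC1)N[C@@H](CCC(=O)OCc1ccccc1)C(=O)OCc1ccccc1` differs from compound 2 by 2-(benzyloxycarbonyl)ethyl in place of sec-butyl on a saturated chain carbon bound to an amide-type nitrogen and a carbonyl carbon. For the measured compounds named here, the one step that bears on this position, a number 3.2 percentage points lower from compound 1 to compound 2 (within the scatter), gives no ground for a shift beyond the scatter in this assay; the expected step is therefore a number 0.6 percentage points higher from compound 2 to compound 4 (within the scatter). Compound 4 is estimated to give 17%, with a range from 7% to 28%.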

Compound 4, a percentage reported as activity, at one dose (the size of the read-out at that dose, not a potency): 14.1%
The estimate for compound 4 lay 2.9 percentage points above the measured number, within the range that was stated.
By their numbers in this assay, from the lowest: compounds 3, 4, 2 and 1 (each within the scatter of the next).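

Putting 2-(benzyloxycarbonyl)ethyl in place of sec-butyl on a saturated chain carbon bound to an amide-type nitrogen and a carbonyl carbon gives a number 2.3 percentage points lower from compound 2 to compound 4 (within the scatter), so even a group with one six-membered aromatic ring and 2 hydrogen-bond acceptors does not separate from sec-butyl. The second exchange at this side chain, a number 5.5 percentage points lower from compound 1 to compound 4 (within the scatter), likewise yields no distinction. No measurement available here accounts for these numbers. Still open, from the compounds shown here alone, is whether a primary amine or a longer unbranched alkyl chain at this position, on the same core, would move the number beyond the scatter in this assay.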